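A few compounds are considered here, and "the series" means these few. Any claim that something is new, unique, unknown or untested is made for them only; others in the source may bear on it.

In a functional assay on A549 cells (Homo sapiens) for antiproliferative activity, read by MTT assay, with a stated time of 72 h (a lower number here means a stronger inhibitor, a higher number a weaker inhibitor), compound 1 (`C=CC(=O)Nc1cccc(Oc2nc(Nc3ccn(C)n3)nc3c2CSCC3)c1`) gives 18600 nM. Compound 2 (`CC/C=C/C(=O)Nc1cccc(Oc2nc(Nc3ccn(C)n3)nc3c2CSCC3)c1`) gives 36800 nM, and compound 3 (`C=C(C)C(=O)Nc1cccc(Oc2nc(Nc3ccn(C)n3)nc3c2CSCC3)c1`) gives 46900 nM. Compound 1 therefore separates clearly only from compound 3: the measured steps are a 2.5-fold higher number from compound 1 to compound 3 (0.40 log units; beyond the scatter) and a 2.0-fold higher number from compound 1 to compound 2 (0.30 log units; within the scatter). The third, a 1.3-fold higher number from compound 2 to compound 3 (0.11 log units; within the scatter), also stays small.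

Compound 4 (`C=CC(=O)Nc1cccc(Oc2nc(Nc3cccc(C#N)c3)nc3c2CSCC3)c1`) carries 3-cyanophenyl in place of 1-methyl-1H-pyrazol-3-yl on a nitrogen on an aromatic ring. All three measured steps change the group on the carbonyl carbon, so none of them touches this place. They indicate only how large steps have been among these three compounds, and they give no direction for the new change. No step beyond the scatter is therefore expected in this assay, though this rests on thin evidence. The expected step is a 1.2-fold lower number from compound 1 to compound 4 (0.09 log units; within the scatter). For compound 4 the estimated value is 15000 nM, with an expected range of 4000 nM to 50000 nM.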

Compound 4, half-maximal inhibitory concentration: 6860 nM
Compound 4: the middle estimate sits 2.2-fold (0.34 log units) above what was measured; the range from low to high includes it.
By their numbers in this assay, from the lowest: compound 4; then compounds 1, 2 and 3 (each within the scatter of the next, the first and the last beyond it).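

In this assay, the place on the nitrogen on an aromatic ring responds to an exchange of rings: 3-cyanophenyl in place of 1-methyl-1H-pyrazol-3-yl gives a 2.7-fold lower number from compound 1 to compound 4 (0.43 log units; beyond the scatter), with the vinyl group on the carbonyl carbon unchanged. This is the only step shown that goes beyond the scatter toward a lower number; the other step beyond it, a 2.5-fold higher number from compound 1 to compound 3 (0.40 log units; beyond the scatter), runs the opposite way and lies on the carbonyl side. Nothing available explains the step on the nitrogen.

This single pair does not separate the contribution of the nitrile from that of the phenyl ring; a plain phenyl group, or an amine or a carboxylic acid in place of the nitrile, would bear on that. Also open, going by these compounds, is how but-1-en-1-yl and 1-methylethenyl on the carbonyl carbon read with 3-cyanophenyl on the nitrogen.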